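Moving from Methylsulfanyl to Iodine on the Urea Phenyl

The compounds below may be only part of what the source reports. "The series", "measured", "known", "first", "only" and "open" are said of these compounds alone.

The study concerns a set of ureas that share a cyclohexyl ether core. Compound 1 `O=C(Nc1cccc(C(F)(F)F)c1)N[C@H]1CC[C@@H](Oc2ccc(F)cc2)CC1` and compound 3 `O=C(Nc1cccc(C(F)(F)F)c1)N[C@H]1CC[C@H](Oc2ccc(OC(F)(F)F)cc2)CC1` both carry a trifluoromethyl-substituted phenyl on the urea; in a functional assay on CRL2813 cells (Homo sapiens) for cytotoxicity, read by sulforhodamine B assay, with a stated time of 5 days (on this read-out lower numbers stand for stronger inhibition and higher numbers for weaker inhibition), compound 1 gives 2600 nM and compound 3 gives 690 nM. Compound 2 `CSc1ccccc1NC(=O)N[C@H]1CC[C@H](Oc2ccc(F)cc2)CC1` carries a methylsulfanyl-substituted phenyl in the same place. For compound 2 this assay reports only a limit, > 20000 nM, so compound 2 stands at the weak end of the numbers shown, the one value of the three that sits at the limit of > 20000 nM in this assay, at which 1 of the 3 values shown sits.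

Compound 4 `O=C(Nc1cccc(I)c1)N[C@H]1CC[C@H](Oc2ccc(F)cc2)CC1` is not yet measured. It differs from compound 2 in one place: 3-iodophenyl in place of 2-(methylsulfanyl)phenyl on an amide-type nitrogen. For the measured compounds named here, no step between two measured compounds isolates this change, so the expectation rests on the spread of the three values. Because compound 1 gives 2600 nM with the same fluorophenyl ether as compound 2 while bearing a different group on the urea nitrogen, the author expects the change in compound 4 to move the read-out beyond the scatter toward stronger inhibition. The expected step in this assay is an at least 6.6-fold lower number from compound 2 to compound 4 (0.82 log units; beyond the scatter). Compound 4 is estimated at 3000 nM, with a range of 800 nM to 12000 nM.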

Compound 4, half-maximal inhibitory concentration: 5200 nM
Compound 4: the middle estimate sits 1.7-fold (0.24 log units) below what was measured, within the range that was stated.
By their numbers in this assay, from the lowest: compound 3; then compounds 1 and 4 (each within the scatter of the next). At a limit, above all of these: compound 2.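

In this assay, 3-iodophenyl in place of 2-(methylsulfanyl)phenyl on an amide-type nitrogen gives an at least 3.8-fold lower number from compound 2 to compound 4 (0.58 log units; beyond the scatter). This is the only step shown between two measured compounds that differ in one place, so it ties a change in the read-out to the group on this nitrogen alone, which the earlier compounds, differing from one another in more than one place, could not do. The step can be stated only as a minimum because compound 2 stands at a limit of the assay and not at a number: the limit of > 20000 nM in this assay, at which 1 of the 4 values shown sits.

What the compounds shown leave open is whether the iodine itself matters or whether the loss of the 2-(methylsulfanyl)phenyl group accounts for the step, since the two groups differ both in the atom they carry and in the numbering of its place on the ring. Going by these compounds, a bromine or a methoxy group in place of the iodine would bear on this question, and how either would read in this assay remains unknown from what is given here.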